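The source may report more compounds than this note shows. Statements on the series, on what has been measured and on what is new or still open speak of the compounds shown alone.

The series shares one core, seen in compound 1 `O=C(O)Cc1sc(COc2ccc(Cl)cc2)nc1-c1ccc(Cl)cc1`, compound 2 `O=C(O)Cc1sc(C(c2ccc(F)cc2)c2ccc(F)cc2)nc1-c1ccco1` and compound 3 `O=C(O)Cc1sc(C(c2ccccc2)c2ccccc2)nc1-c1ccc(F)c(F)c1`. In an in vitro assay on HEK385-7 cells for displacement of a labelled ligand from prostaglandin D2 receptor 2 (Homo sapiens) (on this read-out higher numbers stand for weaker inhibition and lower numbers for stronger inhibition), compound 1 gives 32 nM, compound 2 gives 18 nM and compound 3 gives 4.1 nM. Compound 2 thus stands second highest of the three numbers: its nearest neighbour is compound 1, whose number lies within the scatter of repeated measurement, while compound 3 sits furthest away, with a number beyond the scatter. Compound 4 `O=C(O)Cc1sc(C(c2ccc(F)cc2)c2ccc(F)cc2)nc1-c1cc(F)nc(F)c1` has not yet been measured in this assay. Compared with compound 2 it carries 2,6-difluoropyridin-4-yl in place of furan-2-yl on an aromatic carbon. Among the compounds with values here, no pair of measured compounds differs in this one place alone, so the effect of the change cannot be read off from the measured compounds; the carboxymethyl group and the large group are kept unchanged. The step expected for compound 4 in this assay is a 1.2-fold lower number from compound 2 to compound 4 (0.08 log units; within the scatter), that is, none beyond the scatter. Compound 4 is therefore estimated at 15 nM, within a range from 4 nM to 60 nM.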

Compound 4, half-maximal inhibitory concentration: 5.4 nM
Compound 4: middle estimate off by 2.8-fold (0.44 log units), on the high side; the range from low to high includes it.
By their numbers in this assay, from the lowest: compounds 3 and 4 (each within the scatter of the next); then compounds 2 and 1 (each within the scatter of the next).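

In this assay, 2,6-difluoropyridin-4-yl in place of furan-2-yl, on the aromatic carbon next to the ring nitrogen, gives a 3.3-fold lower number from compound 2 to compound 4 (0.52 log units; beyond the scatter). Within the data shown here, this is the first single-place comparison at this position, and it shows that the position responds to the choice of group and accepts a six-membered aromatic ring with more heavy atoms without loss, while the carboxymethyl group and the large group stay unchanged. The two groups do not differ in their counts of hydrogen-bond donors and acceptors, and nothing measured here accounts for the step.

On these data alone, it remains open whether the ring nitrogen or the two fluorines matter more, which a plain pyridin-4-yl or a phenyl group at this position could help to separate. As far as these compounds go, whether the step carries over to other large groups also remains open.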